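The compounds below may be only part of what the source reports. "The series", "measured", "known", "first", "only" and "open" are said of these compounds alone.

Compound 2 `Cc1nc(S(C)(=O)=O)ccc1Oc1ncnc(OC2CCN(C(=O)C(C)(C)F)CC2)c1F` is the weaker of the two measured compounds: in a functional assay on isolated protein for inhibition of Glucose-dependent insulinotropic receptor (Homo sapiens), read by HTRF and cAMP accumulation (on this read-out lower numbers stand for an effect already at smaller amounts and higher numbers for an effect only at larger amounts of compound), compound 2 gives 76.3 nM, whereas compound 1 `Cc1nc(S(C)(=O)=O)ccc1Oc1ncnc(OC2CCN(C(=O)SC(C)(C)C)CC2)c1F` gives 4.83 nM. Within the data shown here, the only measured step, a 16-fold higher number from compound 1 to compound 2 (1.20 log units; beyond the scatter), shows that exchanging the group on the carbonyl carbon shifts the number strongly. Compound 3 `Cc1nc(S(C)(=O)=O)ccc1Oc1ncnc(OC2CCN(C(=O)C3CCCC3)CC2)c1F` differs from compound 2 by cyclopentyl in place of 1-fluoro-1-methylethyl on a carbonyl carbon. Among the measured compounds shown here, no measured step covers a change between two carbon-only groups at this carbonyl, so the direction is uncertain; given that the sole step a 16-fold higher number from compound 1 to compound 2 (1.20 log units; beyond the scatter) was large, compound 3 is expected to move modestly back toward lower numbers, a 3.1-fold lower number from compound 2 to compound 3 (0.48 log units; beyond the scatter), with an estimated value of 25 nM (range 5 nM to 120 nM).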

Compound 3, half-maximal effective concentration: 72.8 nM
For compound 3 the middle estimate is 2.9-fold (0.46 log units) below the measured one; the measured number falls inside the stated range.
By their numbers in this assay, from the lowest: compound 1; then compounds 3 and 2 (each within the scatter of the next).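

In this assay, the step to cyclopentyl, a 1.0-fold lower number from compound 2 to compound 3 (0.02 log units; within the scatter), shows that this position does not separate these two carbon-attached groups. The step of a 15-fold higher number from compound 1 to compound 3 (1.18 log units; beyond the scatter), repeats the large gap seen with compound 2, so among these compounds only the (tert-butyl)sulfanyl group of compound 1 stands apart. Nothing available here offers an explanation for that gap. From the compounds shown here alone, it remains open whether an amine or a plain tert-butyl group on the carbonyl carbon would read like compound 1 or like compounds 2 and 3.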